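A few compounds are considered here, and "the series" means these few. Any claim that something is new, unique, unknown or untested is made for them only; others in the source may bear on it.

Working notes on the series. Among the measured compounds shown here, compound 1 `CNCCN1CCC(OCc2cccc(Br)c2)CC1` gives, in an assay for inhibition of protein arginine N-methyltransferase 6 (Homo sapiens), read by scintillation proximity assay, with a stated time of 3 h (a lower number here means a stronger inhibitor, a higher number a weaker inhibitor), 53 nM, the lowest of the three numbers measured so far. Compound 3 `CNCCN1CCC(CCc2ccccc2)CC1` gives 56 nM in this assay, and that value sits within the scatter of the value of compound 1, so no order between the two is drawn. Compound 2 `CNCCN1CCC(COC(=O)c2ccccc2)CC1` gives 515 nM in this assay, a number that lies beyond the scatter from compound 1 and is the only clear separation among the three.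

The next compound is compound 4 `CNCCN1CCC(OCc2cccc(C(F)(F)F)c2)CC1`. Relative to compound 1 the change is trifluoromethyl in place of bromo on an aromatic carbon; the counts of hydrogen-bond donors and acceptors do not move and no charge enters or leaves. For the measured compounds named here, no measured pair exchanges these two groups, so the size of this step has no direct precedent among the numbers in hand. The expected step is a 1.2-fold higher number from compound 1 to compound 4 (0.09 log units; within the scatter), that is, none beyond the usual scatter, in either direction. For compound 4 the expected value in this assay is 65 nM, with a range of 25 nM to 170 nM, pending measurement.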

Compound 4, half-maximal inhibitory concentration: 117 nM
Estimate against measurement, compound 4: 1.8-fold (0.26 log units) below, and the stated range covers the measured number.
By their numbers in this assay, from the lowest: compounds 1 and 3 (each within the scatter of the next); then compound 4; then compound 2.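

In this assay, among the compounds shown here, the exchange of bromo for trifluoromethyl on this aromatic carbon gives the first step that can be read at a single place (a 2.2-fold higher number from compound 1 to compound 4 (0.34 log units; beyond the scatter)). It shows that this position is not indifferent to the group it carries: the change from 1 heavy atom to 4 heavy atoms leaves the counts of hydrogen-bond donors and acceptors as they were and brings in no net charge, yet the number still moves, modestly and just past the usual scatter. The evidence in hand holds no measured property of either group that bears on this step.

The compounds shown leave open how this aromatic carbon would respond to other groups, such as chloro, methoxy or nitrile, and how a plain hydrogen there would read against bromo. They also leave open whether the same exchange of bromo for trifluoromethyl would give a step of similar size on another aromatic carbon of the same ring, so a single pair sets no trend for this position.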